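A few compounds are considered here, and "the series" means these few. Any claim that something is new, unique, unknown or untested is made for them only; others in the source may bear on it.

In a functional assay on RAW264.7 cells (Mus musculus) for inhibition, read by Griess assay, with stated times of 3 h and 24 h (on this read-out higher numbers stand for weaker inhibition and lower numbers for stronger inhibition), compound 1 `C=C1CC[C@H]2[C@@](C)(CC[C@@H](OC(=O)c3cccnc3)[C@@]2(C)NC=O)[C@@H]1/C=C/C1=CCOC1=O` gives > 50000 nM, which is a limit of the assay and not a number. Within the data shown here, compound 2 `C=C1CC[C@H]2[C@@](C)(CC[C@@H](OC(=O)c3ccccc3)[C@@]2(C)NC=O)[C@@H]1/C=C/C1=CCOC1=O` gives 50000 nM, the only true number so far, so nothing measured yet ranks it against a neighbour. Placing phenyl where pyridin-3-yl stood on a carbonyl carbon makes the one measured step, a number no higher from compound 1 to compound 2 (the limit leaves the size open), and its size stays open because of the limit of > 50000 nM in this assay, at which 1 of the 2 values shown sits. Compound 3 `C=C1CC[C@H]2[C@@](C)(CC[C@@H](OC(=O)c3ccc([N+](=O)[O-])cc3)[C@@]2(C)NC=O)[C@@H]1/C=C/C1=CCOC1=O` differs from compound 2 in one place: nitro in place of hydrogen on an aromatic carbon, para to a large group. The step of a number no higher from compound 1 to compound 2 (the limit leaves the size open) changed the same aromatic group but offers no size to carry over, so no shift beyond the scatter is expected in this assay. The expected step is a 1.3-fold lower number from compound 2 to compound 3 (0.10 log units; within the scatter). Compound 3 is estimated at 40000 nM, with an expected range of 15000 nM to 80000 nM.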

Compound 3, half-maximal inhibitory concentration: > 50000 nM
Compound 3: a limit, no number (the forecaster's own chance of this, stated with the estimate: 40%); at least 1.2-fold (0.09 log units) between middle value and limit.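

In this assay, nitro on the aromatic carbon para to a large group gives a number no lower from compound 2 to compound 3 (the limit leaves the size open), so adding this group to the phenyl of compound 2 brings no lower number. Compound 3 gives > 50000 nM, which is a limit of the assay and not a number, and the steps that end at this limit cannot be read for size. The change may therefore be small or large, and no ranking can be drawn, because the values crowd at one ceiling: the limit of > 50000 nM in this assay, at which 2 of the 3 values shown sit.

As far as these compounds go, whether an amine or a carboxylic acid at this same place on the phenyl would give a number clearly lower than that of compound 2 stays open. Also open, from the compounds shown here alone, is whether a longer chain in place of the phenyl, on the same carbonyl carbon, would change the read-out.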